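This account rests on a few compounds, and the source may have more. Where it says the series, first, only, none or still open, it means among the compounds named here.

Of the compounds shown here, two built on a shared core have so far been tested in an ADME assay on microsomes from liver (Rattus norvegicus) for metabolic stability, read by LC-MS, using NADPH, with a stated time of 30 min, tested at 0.1 uM; a lower number here means that less of the compound is left, a higher number that more of the compound is left. In this test, compound 1 (`O=S(=O)(NCCN1CCCC1)c1cccc(-c2ccc3nccc(-c4ccnc(C(F)(F)F)c4)c3n2)c1`) gives 16% and compound 2 (`O=S(=O)(CCO)c1cccc(-c2ccc3nccc(-c4ccncc4)c3n2)c1`) gives 59%. Compound 2 therefore holds the higher of the two numbers, and the gap between them is larger than the usual scatter of repeated measurements. The two compounds differ in more than one place, so this gap cannot be assigned to any single group.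

The next compound, compound 3 (`CS(=O)(=O)Nc1cccc(-c2ccc3nccc(-c4ccncc4)c3n2)c1`), keeps the core of compound 2 and changes one group: methanesulfonamido in place of (2-hydroxyethyl)sulfonyl on an aromatic carbon, meta to a large group (methanesulfonamido in place of (2-hydroxyethyl)sulfonyl on an aromatic carbon). Among the compounds with values here, no measured pair shows what this exchange does, so the starting point is compound 2 at 59%. A step beyond the scatter in either direction is not expected, although the estimate leans slightly downward, with an expected change of a number 7 percentage points lower from compound 2 to compound 3 (within the scatter). For compound 3 the expected value is 52%, with an estimated range from 28% to 76%.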

Compound 3, percent of the compound remaining: 49%
Compound 3: the middle estimate sits 3 percentage points above what was measured; measured number inside the range.
By their numbers in this assay, from the lowest: compound 1; then compounds 3 and 2 (each within the scatter of the next).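

In this assay, within the data shown here, this is the first comparison in which only one place differs: putting methanesulfonamido in place of (2-hydroxyethyl)sulfonyl on an aromatic carbon, meta to a large group, gives a number 10 percentage points lower from compound 2 to compound 3 (within the scatter), so the step does not separate the two groups in this test. At this position, then, the measured amount of compound left does not depend clearly on which of these two groups is present, even though one group carries a nitrogen and the other a hydroxyl-bearing chain. Nothing available here explains this result or links it to a measured property of either group.

Still open, from the compounds shown here alone, is whether other groups on the same aromatic carbon, such as a simple amine, a carboxylic acid or a longer chain on the sulfonamide nitrogen, would also stay within the scatter of compound 2 and compound 3. The shown compounds also leave open how much the trifluoromethyl group of compound 1 and how much its side chain each contribute to its number, since neither is varied alone.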